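A few compounds are considered here, and "the series" means these few. Any claim that something is new, unique, unknown or untested is made for them only; others in the source may bear on it.

Working notes on the series. Among the compounds with values here, in a functional assay on HOS cells (Homo sapiens) for antiproliferative activity (a lower number here means a stronger inhibitor, a higher number a weaker inhibitor), compound 1 (`Nc1n[nH]c(N)c1/N=N/c1cccc2c1CCCC2`) gives 92000 nM, the only numeric value so far. Compound 2 (`Nc1n[nH]c(N)c1/N=N/c1cccc([N+](=O)[O-])c1`) reads > 100000 nM, which is a limit of the assay and not a number. Compound 3 (`Nc1n[nH]c(N)c1/N=N/c1ccc([N+](=O)[O-])cc1`) reads > 100000 nM, which is likewise a limit. Compound 2 therefore stands at the limit of > 100000 nM in this assay, at which 2 of the 3 values shown sit.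

The next compound is compound 4 (`Nc1n[nH]c(N)c1/N=N/c1cccc(O)c1`), with hydroxy in place of nitro on an aromatic carbon. Within the data shown here, no measured step isolates this change, and the starting point is only a limit. A modest move toward lower numbers in this assay is expected, and a result that stays at the limit remains possible. Among the measured compounds shown here, the only numeric guide is compound 1 at 92000 nM. In numbers, the expected change is an at least 1.6-fold lower number from compound 2 to compound 4 (0.22 log units; that floor lies within the scatter). For compound 4 the estimated value is 60000 nM, with an expected range of 20000 nM to 100000 nM.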

Compound 4, half-maximal inhibitory concentration: > 100000 nM
Compound 4: only a limit was reported; the forecaster's own chance of this, stated with the estimate: 35%; middle value at least 1.6-fold (0.22 log units) away from the limit.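

Compound 4 reads > 100000 nM, a limit of the assay and not a number, and compound 2 is also only a limit, so no step can be read between these two compounds. The compounds shown leave open whether hydroxy in place of nitro on an aromatic carbon changes the result in this assay at all.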